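The compounds below may be only part of what the source reports. "The series", "measured", "known", "first", "only" and "open" are said of these compounds alone.

Measured so far:
compound 1 `Cc1ccccc1Nc1nc(SCc2cn(Cc3ccccc3Cl)nn2)nc(-c2ccccc2)c1C#N` with 9740 nM
compound 2 `Cc1ccc(Cn2cc(CSc3nc(Nc4ccc(C)cc4)c(C#N)c(-c4ccccc4)n3)nn2)cc1` with 55700 nM

In a functional assay on ECa-109 cells (Homo sapiens) for inhibition, read by MTT assay, with a stated time of 72 h (a lower number here means a stronger inhibitor, a higher number a weaker inhibitor), compound 2 gives the highest of the two numbers, and its nearest neighbour, compound 1, sits at a gap that lies beyond the usual scatter. Within the data shown here, compound 1 and compound 2 differ at two places, so their numbers show only that the pair is far apart, not which place matters. Compound 3 `Cc1ccc(Nc2nc(SCc3cn(Cc4ccccc4Cl)nn3)nc(-c3ccccc3)c2C#N)cc1` is not yet measured. It differs from compound 2 by 2-chlorophenyl in place of 4-methylphenyl on a saturated chain carbon bound to an aromatic nitrogen, and this single change leaves compound 3 sharing the 2-chlorobenzyl group with compound 1. A move toward a lower number is expected, of moderate size, because compound 1 carries that same group and gives 9740 nM. The step from a 2.8-fold lower number from compound 2 to compound 3 (0.44 log units; beyond the scatter) is therefore expected to point downward, beyond the scatter but not as far as the whole gap to compound 1. For compound 3 the expected value is 20000 nM, within 6000 nM to 60000 nM.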

Compound 3, half-maximal inhibitory concentration: > 64000 nM
Compound 3 ended at the assay's limit (the forecaster's own chance of this, stated with the estimate: 10%); middle value at least 3.2-fold (0.50 log units) from the limit.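

In this assay compound 3 gives > 64000 nM, which is a limit of the assay and not a number. Putting 4-methylphenyl in place of 2-methylphenyl on a nitrogen on an aromatic ring gives an at least 6.5-fold higher number from compound 1 to compound 3 (0.81 log units; beyond the scatter), so this one place, taken alone, is enough to produce a gap beyond the scatter. Putting 2-chlorophenyl in place of 4-methylphenyl on a saturated chain carbon bound to an aromatic nitrogen gives an at least 1.1-fold higher number from compound 2 to compound 3 (0.06 log units; that floor lies within the scatter), so the 2-chlorobenzyl group does not by itself bring the lower number that compound 1 shows.

From the compounds shown here alone, how far compound 3 really lies past its limit remains open, and with it the true size of the 2-chlorobenzyl change. Also open, going by these compounds, is how a plain phenyl group, or a phenyl group carrying a carboxylic acid, would behave on that nitrogen.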